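From compound 3 to compound 4: a new group on nitrogen

The source may hold more compounds than are shown below. What is called first, only, known or untested is meant among the compounds shown, and "the series" means these compounds.

Measured so far in an ADME assay on HUVEC cells (Homo sapiens) for inhibition, read by CCK-8 assay, with a stated time of 24 h, in the presence of a further agent that is not named here; on this read-out higher numbers stand for weaker inhibition and lower numbers for stronger inhibition:
- compound 1 `O=C1Nc2ccccc2/C1=C/c1ccc(-c2cn(-c3ccc(Cl)c(C(F)(F)F)c3)nn2)cc1` gives > 20000 nM as a limit
- compound 2 `Cc1ccc(-n2cc(-c3ccc(/C=C4\C(=O)Nc5ccc(F)cc54)cc3)nn2)cc1` gives 13800 nM
- compound 3 `O=C1Nc2ccc(F)cc2/C1=C/c1ccc(-c2cn(-c3ccccc3Cl)nn2)cc1` gives 18200 nM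

Compound 3 gives 18200 nM and stands within the scatter of compound 2 at 13800 nM in this assay as the other numerical reading. Compound 1 stands at > 20000 nM and this is a limit of the assay and not a number.

Compound 4 `O=C1Nc2ccc(F)cc2/C1=C/c1ccc(-c2cn(-c3ccc(Cl)c(C(F)(F)F)c3)nn2)cc1` has 4-chloro-3-(trifluoromethyl)phenyl in place of 2-chlorophenyl on an aromatic nitrogen, and the counted change is 4-chloro-3-(trifluoromethyl)phenyl in place of 2-chlorophenyl on an aromatic nitrogen on top of an otherwise unchanged structure.

For the measured compounds named here, the one measured step at this nitrogen is a 1.3-fold higher number from compound 2 to compound 3 (0.12 log units; within the scatter) and it gives no sign of a large response to the group placed there. Compound 1 carries the same 4-chloro-3-(trifluoromethyl)phenyl group, and its reading is the limit > 20000 nM in a sentence of its own right.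

No step beyond the scatter is therefore expected, and no direction is assigned: the expected change is a 1.1-fold lower number from compound 3 to compound 4 (0.06 log units; within the scatter) in this assay as a working figure. A limit instead of a number is also a real expectation for compound 4 given the limit of > 20000 nM in this assay, at which 1 of the 3 values shown sits, in this series. The estimate for compound 4 is 16000 nM (range 8000 nM to 26000 nM).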

Compound 4, half-maximal inhibitory concentration: > 20000 nM
Compound 4 was reported as a limit (the forecaster's own chance of this, stated with the estimate: 40%); at least 1.2-fold (0.09 log units) between middle value and limit.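

In this assay, 4-chloro-3-(trifluoromethyl)phenyl on the aromatic nitrogen gives an at least 1.0-fold higher number from compound 3 to compound 4 (0.04 log units; that floor lies within the scatter) against 2-chlorophenyl, and an at least 1.4-fold higher number from compound 2 to compound 4 (0.16 log units; that floor lies within the scatter) against 4-methylphenyl. Both are floors within the scatter, so this position has still shown no step that clearly exceeds the scatter, though neither floor fixes the real size of the change, which is the point compound 3 and compound 2 alone could not raise. Compound 1 and compound 4, the two compounds shown with this group, both read as a limit and not as a number, so the step for fluoro in place of hydrogen on an aromatic carbon cannot be read, and the limit now recurs in the series: the limit of > 20000 nM in this assay, at which 2 of the 4 values shown sit.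

From the compounds shown here alone, whether a group of another kind on this nitrogen, such as a carboxylic acid, an amine or a longer chain ending in an amine, would shift the reading beyond the scatter remains open. Also open, going by these compounds, is what the fluoro contributes when 4-chloro-3-(trifluoromethyl)phenyl sits on the nitrogen.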